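Amide to urea: one step on a shared core

The source may report more compounds than this note shows. Statements on the series, on what has been measured and on what is new or still open speak of the compounds shown alone.

Measured so far:
compound 1 `COc1cc(-c2nn(-c3cccc(NC(=O)c4cccc(C(F)(F)F)c4)c3)cc2-c2ccncc2)ccc1Cl` — 2460 nM
compound 2 `O=C(Nc1cccc(-n2cc(-c3ccncc3)c(-c3ccc(Cl)c(O)c3)n2)c1)Nc1ccc(Cl)c(Cl)c1` — 1460 nM

In a functional assay on SNB-19 cells (Homo sapiens) for inhibition, read by sulforhodamine B assay, with a stated time of 48 h (on this read-out higher numbers stand for weaker inhibition of growth and lower numbers for stronger inhibition of growth), compound 1 gives 2460 nM, the highest of the two numbers shown. Compound 2 gives 1460 nM, which lies within the scatter of compound 1, so no order between the two is claimed. Compound 3 `COc1cc(-c2nn(-c3cccc(NC(=O)Nc4cccc(C(F)(F)F)c4)c3)cc2-c2ccncc2)ccc1Cl` differs from compound 1 by (3-(trifluoromethyl)phenyl)amino in place of 3-(trifluoromethyl)phenyl on a carbonyl carbon. Within the data shown here, no pair of measured compounds isolates this change; compound 2 differs from compound 1 in more than one place, so its value only shows that a number of this size is reachable on the shared core. The expectation for compound 3 is a step toward a lower number that stays within the scatter, a 1.6-fold lower number from compound 1 to compound 3 (0.21 log units; within the scatter). Compound 3 is estimated in this assay at 1500 nM, with a range from 500 nM to 4500 nM.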

Compound 3, concentration for 50% growth inhibition: 981 nM
The estimate for compound 3 lay 1.5-fold (0.18 log units) above the measured number, and the stated range covers the measured number.
By their numbers in this assay, from the lowest: compounds 3, 2 and 1 (each within the scatter of the next, the first and the last beyond it).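

In this assay, among these compounds, (3-(trifluoromethyl)phenyl)amino in place of 3-(trifluoromethyl)phenyl on a carbonyl carbon gives a 2.5-fold lower number from compound 1 to compound 3 (0.40 log units; beyond the scatter), the first reading of a change at this position with the rest of the molecule held fixed. The step is modest, but it shows that this position responds to a single change and that the larger group, which carries one hydrogen-bond donor, is accepted on the shared core. No available measurement bears on why the number falls with this change.

Still open, from the compounds shown here alone, is whether the amino nitrogen itself matters, which a methylene or an oxygen in its place, or a methyl group on that nitrogen, could test. Also open, going by these compounds, is whether the step holds when a nitrile or a chlorine replaces the trifluoromethyl group.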